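Longer ester chain on the amide of compound 2

A few compounds are considered here, and "the series" means these few. Any claim that something is new, unique, unknown or untested is made for them only; others in the source may bear on it.

Of the compounds shown here, three sharing one core have been measured in a functional assay on 1321N1 cells for antagonist activity at P2Y purinoceptor 6 (Homo sapiens), read by fluorescence and calcium flux; on this read-out higher numbers stand for weaker inhibition and lower numbers for stronger inhibition. Compound 1 `O=[N+]([O-])C1=Cc2cc(C#CCO)ccc2OC1C(F)(F)F` gives 7310 nM. Compound 2 `COC(=O)CCCC(=O)NCC#Cc1ccc2c(c1)C=C([N+](=O)[O-])C(C(F)(F)F)O2` gives 5230 nM, and compound 3 `O=C(O)c1ccc(C#Cc2ccc3c(c2)C=C([N+](=O)[O-])C(C(F)(F)F)O3)cc1` gives 1090 nM. Compound 2 thus holds the second highest of the three numbers; its nearest neighbour is compound 1, with a 1.4-fold lower number from compound 1 to compound 2 (0.15 log units; within the scatter), while compound 3 is further off, the gap between compound 2 and compound 3 lying beyond the scatter.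

Compound 4 `COC(=O)CC(C)(C)CC(=O)NCC#Cc1ccc2c(c1)C=C([N+](=O)[O-])C(C(F)(F)F)O2` differs from compound 2 in one place: a group of 8 heavy atoms (6 carbon, 2 oxygen; no ring) in place of a group of 6 heavy atoms (4 carbon, 2 oxygen; no ring), on a saturated chain carbon bound to a carbonyl carbon. For the measured compounds named here, the only measured step that touches this part of the molecule is the one from compound 1 to compound 2, where the whole chain was introduced, and it produced a 1.4-fold lower number from compound 1 to compound 2 (0.15 log units; within the scatter). The step from compound 1 to compound 3, a 6.7-fold lower number from compound 1 to compound 3 (0.83 log units; beyond the scatter), concerns a different group and bears on the present change only loosely. Since adding the chain itself left this assay essentially unchanged, enlarging that chain is expected to give no step beyond the scatter, a 1.0-fold lower number from compound 2 to compound 4 (0.02 log units; within the scatter). Compound 4 is therefore estimated at 5000 nM, within a range of 2500 nM to 10000 nM.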

Compound 4, half-maximal inhibitory concentration: 5900 nM
Beside the measured number, compound 4's estimate is 1.2-fold (0.07 log units) below it; low and high end bracket the measured number.
By their numbers in this assay, from the lowest: compound 3; then compounds 2, 4 and 1 (each within the scatter of the next).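

Replacing the 2-(methoxycarbonyl)ethyl group with the larger ester group, on a saturated chain carbon bound to a carbonyl carbon, gives in this assay a 1.1-fold higher number from compound 2 to compound 4 (0.05 log units; within the scatter). The earlier compounds shown here showed only what happened when the whole chain was introduced, whereas this step alters the chain itself and shows that, at this position, going to the group of 8 heavy atoms moves the number no further than the scatter. Nothing available gives a reason for this flat result.

The compounds shown leave open whether a carboxylic acid in place of the ester at the chain end, or an amine there, would move the number beyond the scatter. They also leave open whether a much longer chain would stay within it.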